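This account rests on a few compounds, and the source may have more. Where it says the series, first, only, none or still open, it means among the compounds named here.

Measured in a functional assay on K562 cells (Homo sapiens) for inhibition, with a stated time of 48 h; on this read-out higher numbers stand for weaker inhibition of growth and lower numbers for stronger inhibition of growth:

Compound 1 `COc1c(C(=O)/C=C/c2ccc(Cl)cc2)c(O)c(Br)c2occc12`: 2880 nM
Compound 2 `C=CCc1c(O)c(C(=O)/C=C/c2ccccc2)c(OC)c2ccoc12`: 2870 nM

Only these two compounds have been measured so far. Compound 2, at 2870 nM, cannot be ranked against compound 1, at 2880 nM, since the two numbers lie within the usual scatter of repeated measurements.

The next compound to test is compound 3 `C=CCc1c(O)c(C(=O)/C=C/c2ccc(Cl)cc2)c(OC)c2ccoc12`. It is compound 2 with chloro in place of hydrogen on an aromatic carbon, para to a large group, so that phenyl becomes 4-chlorophenyl: chloro in place of hydrogen on an aromatic carbon.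

Within the data shown here, no measured pair shows this single change on its own. Among the measured compounds shown here, the only hint comes from compound 1, which already carries a 4-chlorophenyl and gives 2880 nM, although it also differs from compound 2 elsewhere on the shared core. As far as these compounds go, that value gives no sign of a large shift, so no step beyond the scatter is expected in this assay, and the direction remains open. The estimated change is a 1.1-fold lower number from compound 2 to compound 3 (0.06 log units; within the scatter). For compound 3 the expected value is 2500 nM, with an estimated range of 1000 nM to 6000 nM.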

Compound 3, concentration for 50% growth inhibition: 3250 nM
For compound 3 the middle estimate is 1.3-fold (0.11 log units) below the measured one; measured number inside the range.
By their numbers in this assay, from the lowest: compounds 2, 1 and 3 (each within the scatter of the next).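

Read on its own for the first time, chloro in place of hydrogen on an aromatic carbon, para to a large group, which turns phenyl into 4-chlorophenyl, gives a 1.1-fold higher number from compound 2 to compound 3 (0.05 log units; within the scatter) in this assay, so on this read-out the change cannot be told apart from no change at all. With the 4-chlorophenyl held fixed, allyl in place of bromo on an aromatic carbon gives a 1.1-fold higher number from compound 1 to compound 3 (0.05 log units; within the scatter), so this second swap, which involves a much larger difference in the group itself, also stays inside what repeated measurements would scatter by, and compounds 1, 2 and 3 cannot be ranked. No supporting measurement is available to explain why either of these changes leaves the number where it is.

The compounds shown leave open whether a group of a different kind, such as an amine or a carboxylic acid, in place of the chloro on the 4-chlorophenyl would give a step beyond the scatter. As far as these compounds go, it also remains open whether a longer chain in place of the allyl would do so.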